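From Methoxy to Ethoxy in a Steep Set

This account rests on a few compounds, and the source may have more. Where it says the series, first, only, none or still open, it means among the compounds named here.

In a functional assay on HCC 2998 cells (Homo sapiens) for antiproliferative activity (a lower number here means a stronger inhibitor of growth, a higher number a weaker inhibitor of growth), compound 1 (`COc1ccc(-c2nc3cc(F)ccc3s2)cc1`) gives 12400 nM and compound 2 (`COc1ccc(-c2nc3cc(F)ccc3s2)cc1C`) gives 540 nM in the same test. Compound 3 (`COc1ccc(-c2nc3cc(F)ccc3s2)cc1OC`) gives 0.25 nM there, the lowest number of the three and beyond the scatter from both of the others.

Compound 4 (`CCOc1cc(-c2nc3cc(F)ccc3s2)ccc1OC`) departs from compound 3 by a single change (methyl in place of hydrogen on a saturated chain carbon bound to an oxygen on an aromatic ring): methyl in place of hydrogen on a saturated chain carbon bound to an oxygen on an aromatic ring, which turns methoxy into ethoxy. Among the measured compounds shown here, no measured step makes exactly this change. The closest in words is a large one (a 23-fold lower number from compound 1 to compound 2 (1.36 log units; beyond the scatter)), but there the methyl goes onto an aromatic carbon. The other two steps (a 50000-fold lower number from compound 1 to compound 3 (4.70 log units; beyond the scatter)) and (a 2200-fold lower number from compound 2 to compound 3 (3.33 log units; beyond the scatter)) are larger still and show how sharply the numbers in this assay move with a small edit to one substituent. Compound 3 already stands very low (0.25 nM), so a further edit seems more likely to raise the number than to lower it. A rise beyond the scatter is therefore expected (a 12-fold higher number from compound 3 to compound 4 (1.08 log units; beyond the scatter)), though its size is uncertain. The estimate for compound 4 is 3 nM with an expected range from 0.1 nM to 150 nM in this measurement.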

Compound 4, concentration for 50% growth inhibition: 3320 nM
Beside the measured number, compound 4's estimate is 1100-fold (3.04 log units) below it, outside the stated range (above it).
By their numbers in this assay, from the lowest: compound 3; then compound 2; then compound 4; then compound 1.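

In this assay, a single methyl added to the saturated chain carbon bound to the oxygen turns methoxy into ethoxy and produces a steep rise (a 13000-fold higher number from compound 3 to compound 4 (4.12 log units; beyond the scatter)), which gives back most of what methoxy gained over hydrogen (a 50000-fold lower number from compound 1 to compound 3 (4.70 log units; beyond the scatter)). Ethoxy also stands on the weaker side of methyl on the same aromatic carbon (a 6.1-fold higher number from compound 2 to compound 4 (0.79 log units; beyond the scatter)) and keeps only a modest edge over hydrogen there (a 3.7-fold lower number from compound 1 to compound 4 (0.57 log units; beyond the scatter)), so among the four groups shown at this place, methoxy gives the lowest number, and growing that group by one carbon does not preserve its effect. Nothing available on these compounds accounts for so sharp a loss from so small an edit.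

The compounds shown leave open whether a hydroxyl or a propoxy chain at this place would fall with ethoxy or stay nearer methoxy. They also leave open whether a fluorine or a chlorine there, with no oxygen attached to the ring, would sit closer to methyl or to hydrogen in this assay.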